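Furan-2-yl in Place of Methoxyphenyl: Expected Cytotoxicity

The source may hold more compounds than are shown below. What is called first, only, known or untested is meant among the compounds shown, and "the series" means these compounds.

Of the compounds shown here, two sharing one core have been measured in an ADME assay on Vero cells (Chlorocebus sabaeus) for cytotoxicity, read by sulforhodamine B assay, with a stated time of 3 days; on this read-out lower numbers stand for higher toxicity in this test and higher numbers for lower toxicity in this test. Compound 1 `CC1=C(C(=O)Nc2ccc(Cl)cc2)C(c2ccccc2)C(C(=O)Nc2ccc(Cl)cc2)=C(C)N1` carries an unsubstituted phenyl on the saturated ring carbon, and in this assay compound 1 gives 15 ug/mL. Compound 2 `COc1ccc(C2C(C(=O)Nc3ccc(Cl)cc3)=C(C)NC(C)=C2C(=O)Nc2ccc(Cl)cc2)cc1` bears a methoxy group on that phenyl, and in this assay compound 2 gives 20 ug/mL. Going by the values given here, the only step measured so far, a 1.3-fold higher number from compound 1 to compound 2 (0.12 log units; within the scatter), leaves the two compounds within the scatter of each other, so compound 2 stands alongside compound 1 rather than apart from it.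

Compound 3 `CC1=C(C(=O)Nc2ccc(Cl)cc2)C(c2ccco2)C(C(=O)Nc2ccc(Cl)cc2)=C(C)N1` differs from compound 2 in one place: furan-2-yl in place of 4-methoxyphenyl on a saturated ring carbon. Among the compounds with values here, no measured step exchanges one aromatic ring for another at this position, so the step from compound 1 to compound 2 offers no guide to its size or direction. With nothing beyond the scatter seen so far, the step of a 1.3-fold lower number from compound 2 to compound 3 (0.10 log units; within the scatter) is expected to stay within the scatter. Compound 3 is therefore estimated at 16 ug/mL, with a range from 6 ug/mL to 40 ug/mL.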

Compound 3, half-maximal cytotoxic concentration: 24 ug/mL
Beside the measured number, compound 3's estimate is 1.5-fold (0.18 log units) below it; the measured number falls inside the stated range.
By their numbers in this assay, from the lowest: compounds 1, 2 and 3 (each within the scatter of the next).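

In this assay, the position on the saturated ring carbon now has a change of the aromatic ring itself, not only a substituent on the phenyl. Furan-2-yl in place of 4-methoxyphenyl, going from 8 heavy atoms to 5, gives a small step (a 1.2-fold higher number from compound 2 to compound 3 (0.08 log units; within the scatter)), and furan-2-yl in place of phenyl also stays inside the scatter (a 1.6-fold higher number from compound 1 to compound 3 (0.20 log units; within the scatter)), so this test does not separate the three aromatic groups. Nothing available explains why the read-out holds across these rings.

Going by these compounds, all three compounds carry an aromatic ring at this position, so it remains open whether a longer alkyl chain there, or an amine or a carboxylic acid on the phenyl, would move the number beyond the scatter. The same question stands for the (4-chlorophenyl)carbamoyl groups, which are identical throughout.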